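Chlorination of the urea phenyl ring in a thienopyrimidine series

The source may report more compounds than this note shows. Statements on the series, on what has been measured and on what is new or still open speak of the compounds shown alone.

Measured compounds: compound 1 `CN(C)CCNc1nc(-c2ccc(NC(=O)Nc3ccccc3)cc2)nc2ccsc12` gives 640 nM; compound 2 `CN(C)CCNc1nc(-c2ccc(NC(=O)Nc3ccccc3Cl)cc2)nc2ccsc12` gives 230 nM; compound 3 `CCN(CC)CCCNc1nc(-c2ccc(NC(=O)Nc3ccccc3Cl)cc2)nc2c(Cl)c(Cl)sc12` gives 330 nM, all in a functional assay on NCI-H460 cells (Homo sapiens) for cytotoxicity, read by MTT assay, with a stated time of 72 h; a higher number here means a weaker inhibitor, a lower number a stronger inhibitor.

Compound 2 differs from compound 1 by chloro in place of hydrogen on an aromatic carbon, a step of a 2.8-fold lower number from compound 1 to compound 2 (0.44 log units; beyond the scatter). The difference between the core of compound 1 and the core of compound 3 is not broken down here. Compound 4 `CCN(CC)CCCNc1nc(-c2ccc(NC(=O)Nc3ccc(Cl)cc3Cl)cc2)nc2c(Cl)c(Cl)sc12` carries the same kind of change relative to compound 3, namely (chloro in place of hydrogen on an aromatic carbon), though the place differs: here the entering chloro sits meta to a chloro group and para to a large group, whereas in compound 2 it sits ortho to a large group. Because the earlier step read a 2.8-fold lower number from compound 1 to compound 2 (0.44 log units; beyond the scatter), compound 4 is expected to give a step of a 1.7-fold lower number from compound 3 to compound 4 (0.22 log units; within the scatter) in this assay, with some caution since the position is not the same. Compound 4 is estimated at 200 nM, between 80 nM and 500 nM.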

Compound 4, half-maximal inhibitory concentration: 1170 nM
Beside the measured number, compound 4's estimate is 5.9-fold (0.77 log units) below it; measured number above the stated range.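

In this assay, a chloro added to the urea phenyl ring does not carry its effect from one core to the other: going from 2-chlorophenyl to 2,4-dichlorophenyl gives a 3.5-fold higher number from compound 3 to compound 4 (0.55 log units; beyond the scatter), whereas the earlier chloro gave a 2.8-fold lower number from compound 1 to compound 2 (0.44 log units; beyond the scatter). The two steps run in opposite directions, and the gap between them exceeds what scatter would explain: the same change on two cores in this assay, a 2.8-fold lower number (0.44 log units; beyond the scatter) from compound 1 to compound 2 and a 3.5-fold higher number (0.55 log units; beyond the scatter) from compound 3 to compound 4, 9.9-fold (0.99 log units) apart, beyond the scatter of two such steps. This does not show that the core alone reverses the effect, since the chloro also enters at a different place in each step, so core and place cannot be separated here.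

Going by these compounds, what remains open is how a 2,4-dichlorophenyl urea would read on the core of compound 1. Also open, on these data alone, is whether a fluoro or methoxy group in place of the entering chloro on compound 4 would read the same way.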